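The source may hold more compounds than are shown below. What is called first, only, known or untested is meant among the compounds shown, and "the series" means these compounds.

Among the compounds with values here, three diaryl compounds share a similar core and were examined in a functional assay on NCI-H1299 cells (Homo sapiens) for cytotoxicity, read by a luciferase reporter and CellTiter-Glo, with a stated time of 72 h (on this read-out higher numbers stand for weaker inhibition and lower numbers for stronger inhibition), but only one produced a number. Compound 1 `COc1ccc(C2=NN(c3cccc(Cl)c3)C(c3cccc(Cl)c3)C2)cc1` is recorded as "not determined" (no result reported), and compound 2 `COc1cccc(C2=NN(c3cccc(Cl)c3)C(c3cccc(Cl)c3)C2)c1` is recorded as "not determined" (no result reported). Within the data shown here, compound 3 `COc1ccccc1C1=NN(c2ccccc2Cl)C(c2cccc(Cl)c2)C1` gives 13400 nM, so it is the only compound with a measured value, and there is nothing to rank it against. Whether this value is high or low within the series cannot yet be said.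

Compound 4 `COc1ccccc1C1=NN(c2cccc(Cl)c2)C(c2cccc(Cl)c2)C1` has not yet been measured. It differs from compound 3 in a single place: 3-chlorophenyl in place of 2-chlorophenyl on an amine nitrogen in a ring. In words, 3-chlorophenyl stands in place of 2-chlorophenyl on an amine nitrogen in a ring. The two compounds therefore have the same atoms, joined differently.

Among the measured compounds shown here, no pair of measured compounds shows what a change of this kind does in this assay, so the data offer no precedent for its size or direction. The expectation therefore stays close to the single anchor, compound 3 at 13400 nM, with no shift beyond the usual scatter in either direction. The expected change is a 1.2-fold lower number from compound 3 to compound 4 (0.09 log units; within the scatter). For compound 4 the estimated value is 11000 nM, with an expected range from 4500 nM to 27000 nM.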

Compound 4, half-maximal inhibitory concentration: 11700 nM
The estimate for compound 4 lay 1.1-fold (0.03 log units) below the measured number, and the stated range covers the measured number.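

On the amine nitrogen in the ring, 3-chlorophenyl in place of 2-chlorophenyl gives a 1.1-fold lower number from compound 3 to compound 4 (0.06 log units; within the scatter) in this assay. Within the data shown here, this is the first pair here that differs in one place, and it shows that these two chlorophenyl groups cannot be told apart on this read-out, since the two compounds have the same atoms and their numbers agree as closely as repeated measurements of one compound would. No measured property of either compound bears on why the two read alike.

From the compounds shown here alone, this one pair tests only where a chlorine sits on the phenyl group at this nitrogen, so it remains open whether an amine or a carboxylic acid on that phenyl group, or a longer chain in its place, would shift the number beyond the scatter. Going by these compounds, compound 1 and compound 2 have no number, so their steps cannot be read, and what the placing of the methoxy group on the other aryl ring does in this assay also stays open.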